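The source may hold more compounds than are shown below. What is called first, only, known or untested is meant among the compounds shown, and "the series" means these compounds.

In a functional assay on HeLa cells (Homo sapiens) for cytotoxicity, read by MTT assay, with a stated time of 72 h (a higher number here means a weaker inhibitor, a lower number a stronger inhibitor), compound 1 `COC(=O)c1sc2c(C)cccc2c1Nc1cc(OC)c(OC)c(OC)c1` gives 1730 nM, while compound 2 `COC(=O)c1sc2nc(C)ccc2c1Nc1cc(OC)c(OC)c(OC)c1` gives 0.18 nM. Compound 2 therefore holds the lower of the two numbers, and the gap between them lies well beyond the scatter of repeated measurements. These two compounds differ in more than one place, however, so their gap does not isolate the effect of any single change. Compound 3 `COC(=O)c1sc2ncccc2c1Nc1cc(OC)c(OC)c(OC)c1` has not yet been measured in this assay. It departs from compound 2 in one place, with hydrogen in place of methyl on an aromatic carbon. Within the data shown here, no measured pair shows what this exchange does, so the expectation remains loose. With compound 2 at 0.18 nM, a number this low leaves more plausible room for a rise than for a further fall. A moderate step upward, beyond the scatter, is therefore expected in this assay, though a step within the scatter cannot be ruled out. The expected change is an 11-fold higher number from compound 2 to compound 3 (1.05 log units; beyond the scatter). For compound 3, the estimated value is 2 nM, with an expected range from 0.2 nM to 40 nM.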

Compound 3, half-maximal inhibitory concentration: 342 nM
Beside the measured number, compound 3's estimate is 170-fold (2.23 log units) below it; the measured number lies above the stated range.
By their numbers in this assay, from the lowest: compound 2; then compound 3; then compound 1.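

Among these compounds, the exchange of methyl for hydrogen gives the first reading of a single change: in this assay, it produces a 1900-fold higher number from compound 2 to compound 3 (3.28 log units; beyond the scatter), a large step. The gap between compound 1 and compound 2 could not be assigned to any one place, whereas this step ties a large change in the number to the methyl on an aromatic carbon next to the ring nitrogen, with the rest of compound 2 left unchanged. So this one position, where a single carbon leaves and no heavy atom enters, is far from indifferent in this assay, but nothing given here explains why the step is so large.

The compounds shown leave open whether an ethyl group, a chlorine atom or an amine on this carbon would keep the number near that of compound 2 or move it towards that of compound 3, and so whether methyl itself matters or only the presence of a heavier group. They also leave open whether hydrogen in place of methyl would have an effect of similar size on the core of compound 1.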